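Arylhydrazone series: pyridinyl replacement in compound 3

The compounds below may be only part of what the source reports. "The series", "measured", "known", "first", "only" and "open" are said of these compounds alone.

Two compounds of the shared core carry a measurement so far. Compound 1 `Cc1ccc(NN=C2CCC(C)n3c2ncc(C(=O)O)c3=O)cc1C` gives 6.5 umol/kg in a functional assay on the whole organism with Rattus norvegicus as the target; a lower number here means that less compound is needed, a higher number that more compound is needed for the effect. Within the data shown here, compound 2 `CC1CCC(=NNc2cc(Cl)cc(Cl)c2)c2ncc(C(=O)O)c(=O)n21` gives 13.3 umol/kg in this assay and thus stands with the higher of the two numbers; the only step between them, a 2.0-fold higher number from compound 1 to compound 2 (0.31 log units; beyond the scatter), comes from exchanging the group on the amine nitrogen.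

The next compound, compound 3 `CC1CCC(=NNc2cccnc2)c2ncc(C(=O)O)c(=O)n21`, differs from compound 2 only on that same amine nitrogen: pyridin-3-yl in place of 3,5-dichlorophenyl on an amine nitrogen. Among the measured compounds shown here, the one measured step that bears on this position, a 2.0-fold higher number from compound 1 to compound 2 (0.31 log units; beyond the scatter), shows that swapping one aryl group for another at this place moves the number only modestly. For the measured compounds named here, no measured compound carries a heteroaryl group here, so the direction for compound 3 cannot be read from the data; the size of the earlier step suggests the change is unlikely to be large.

The step from compound 2 to compound 3 is therefore expected to be a 1.1-fold lower number from compound 2 to compound 3 (0.04 log units; within the scatter) in this assay, most plausibly within the scatter. Compound 3 is estimated at 12 umol/kg in this assay, with a range from 4 umol/kg to 40 umol/kg.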

Compound 3, dose for 50% inhibition: 0.54 umol/kg
Compound 3: middle estimate off by 22-fold (1.35 log units), on the high side; the whole stated range lies above it.
By their numbers in this assay, from the lowest: compound 3; then compound 1; then compound 2.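

The amine nitrogen position is far more sensitive to the choice of aryl group than the earlier step between two carbon-only rings indicated: in this assay, the change to pyridin-3-yl gives a 25-fold lower number from compound 2 to compound 3 (1.39 log units; beyond the scatter) and also a 12-fold lower number from compound 1 to compound 3 (1.08 log units; beyond the scatter) as a second large step in the same direction. Both steps clearly exceed the earlier one (a 2.0-fold higher number from compound 1 to compound 2 (0.31 log units; beyond the scatter)), and among these three compounds the lower number appears whichever substituted phenyl group leaves, with no compound going against this. No evidence at hand bears on the reason for this change.

The compounds shown leave open whether the gain depends on the ring nitrogen or on the loss of the phenyl substituents, a question that unsubstituted phenyl would help separate, and whether pyridin-2-yl or pyridin-4-yl would behave like pyridin-3-yl. Also open, from the compounds shown here alone, is whether a pyridin-3-yl ring bearing a chlorine atom or a methyl group, or a pyrimidinyl group in its place, would keep the low number seen for compound 3 (0.54 umol/kg).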